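The compounds below may be only part of what the source reports. "The series", "measured", "known", "first", "only" and "open" are said of these compounds alone.

Measured so far in a functional assay on SMMC-7721 cells (Homo sapiens) for antiproliferative activity, read by CCK-8 assay, with a stated time of 72 h; a higher number here means a weaker inhibitor, a lower number a stronger inhibitor:
- compound 1 `COc1ccc(SCc2ccc(C(=O)Nc3ccccc3N)cc2)cc1`: 2170 nM
- compound 2 `Nc1ccccc1NC(=O)c1ccc(CSc2cccc(F)c2)cc1`: 3280 nM

In this assay, for the measured compounds named here, compound 2 gives 3280 nM, and with only two numbers in hand it lies within the scatter of compound 1 at 2170 nM. The next compound is compound 3 `Nc1ccccc1NC(=O)c1ccc(CSCCc2ccccc2)cc1`, which carries phenethyl in place of 3-fluorophenyl on a sulfur. The sulfur's other neighbour, a saturated chain carbon, stays the same.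

Going by the values given here, only one measured step bears on this change: a 1.5-fold higher number from compound 1 to compound 2 (0.18 log units; within the scatter). It also exchanges the group on the sulfur, and it stays within the scatter. However, it joins two compounds that both have a ring directly on the sulfur, so it does not test the phenethyl group. Among the compounds with values here, no measured compound carries that group, and the data therefore give no direction for the step. A step beyond the scatter in this assay is not expected, though the uncertainty is wide.

For compound 3 the expected value is 2800 nM, with an estimated range of 1000 nM to 8000 nM. The expected step is a 1.2-fold lower number from compound 2 to compound 3 (0.07 log units; within the scatter).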

Compound 3, half-maximal inhibitory concentration: 4880 nM
Beside the measured number, compound 3's estimate is 1.7-fold (0.24 log units) below it; measured number inside the range.
By their numbers in this assay, from the lowest: compounds 1, 2 and 3 (each within the scatter of the next, the first and the last beyond it).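

In this assay, for the compounds shown here, phenethyl is the first group here that places a saturated chain, rather than an aromatic ring, directly on the sulfur, and the exchange for 3-fluorophenyl gives a 1.5-fold higher number from compound 2 to compound 3 (0.17 log units; within the scatter), so this position accepts that change without a step beyond the scatter on this comparison. Going by these compounds alone, the exchange for 4-methoxyphenyl gives a 2.2-fold higher number from compound 1 to compound 3 (0.35 log units; beyond the scatter) and is the only step among the three compounds that passes the scatter, a modest move toward a weaker inhibitor, so the reading of phenethyl depends on which ring-bearing compound serves as the reference. Nothing available on these groups accounts for either step.

The compounds shown leave open whether a benzyl group or a longer phenylpropyl chain on the sulfur would give a number different from that of phenethyl, and whether a methoxy group or fluorine on the phenethyl ring would carry over what is seen with the directly attached rings. They also leave open how a basic amine or a carboxylic acid at the end of the chain would read in this assay.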